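A few compounds are considered here, and "the series" means these few. Any claim that something is new, unique, unknown or untested is made for them only; others in the source may bear on it.

Measured in an ADME assay on HL-60 cells (Homo sapiens) for cytotoxicity, read by MTT assay, with a stated time of 24 h; on this read-out lower numbers stand for stronger inhibition and higher numbers for weaker inhibition:

Compound 1 `CC(C)CCCN(C)Cc1ccc(C2=CCCN(C)C2)cc1`: > 50000 nM
Compound 2 `COC(=O)c1ccc(CN(C)Cc2ccc(C3=CCCN(C)C3)cc2)cc1`: > 50000 nM
Compound 3 `CN1CCC=C(c2ccc(CN(C)C/C=C/c3ccc([N+](=O)[O-])cc3)cc2)C1`: > 50000 nM

Each of these entries is a limit of the assay and not a number. Compound 1 therefore has no exact position, and the same is true of the whole set, with the limit of > 50000 nM in this assay, at which 3 of the 3 values shown sit. Among the measured compounds shown here, no step between two measured compounds can be counted from such readings.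

Compound 4 `CN1CCC=C(c2ccc(CN(C)CCCc3ccccc3)cc2)C1` keeps the core of compound 1 and differs in one place. (phenyl in place of isopropyl on a saturated chain carbon, three bonds along the chain from an amine nitrogen). In words, this is phenyl in place of isopropyl on a saturated chain carbon, three bonds along the chain from an amine nitrogen.

Adding an aromatic ring to the chain on the amine need not change the picture. Compound 2 carries such a ring, and its value is the limit > 50000 nM. Compound 3 carries one too, and its value is the limit > 50000 nM.

In this assay, no step beyond the usual scatter is expected, and another limit is the most likely reading. As a number, the expected change is a number no higher from compound 1 to compound 4 (the limit leaves the size open). For compound 4 the estimated value is 50000 nM, with an expected range of 20000 nM to 100000 nM.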

Compound 4, half-maximal inhibitory concentration: > 50000 nM
Compound 4: no number, only a limit; the forecaster's own chance of this, stated with the estimate: 75%; the middle value sits exactly at the limit.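

In this assay compound 4 gives > 50000 nM and this is a limit of the assay, not a number. Among the compounds shown here, compound 1 also has only a limit, so no step from compound 1 to compound 4 can be read. Every reading shown stands at the same point: the limit of > 50000 nM in this assay, at which 4 of the 4 values shown sit. The compounds shown leave open how they would rank against one another, and at what concentration, if any, each would harm these cells.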